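The compounds below may be only part of what the source reports. "The series", "measured", "known", "first", "only" and "open" are said of these compounds alone.

Compound 1 `C=CC1=C(C(=O)NCc2ccc(Cl)cc2)C(c2ccc(F)cc2)OC1` is the anchor of this small set. In a functional assay on QGY7701 cells (Homo sapiens) for cytotoxicity, read by MTT assay, with a stated time of 24 h (on this read-out higher numbers stand for weaker inhibition and lower numbers for stronger inhibition), compound 1 gives 36900 nM. Compound 2 `C=CC1=C(C(=O)NCCCCC)C(c2ccc(F)cc2)OC1` differs from compound 1 by butyl in place of 4-chlorophenyl on a saturated chain carbon bound to an amide-type nitrogen. In this assay compound 2 returns only a limit, > 100000 nM. The step of an at least 2.7-fold higher number from compound 1 to compound 2 (0.43 log units; beyond the scatter) is therefore bounded by the limit of > 100000 nM in this assay, at which 2 of the 3 values shown sit. Compound 3 `C=CC1=C(C(=O)NCc2ccc(Cl)cc2)C(c2ccc(OC)cc2)OC1` and the unmeasured compound 4 `C=CC1=C(C(=O)NCCCCC)C(c2ccc(OC)cc2)OC1` share a core that differs from that of compound 1 by methoxy in place of fluoro on an aromatic carbon. In this assay compound 3 also returns only a limit, > 100000 nM. The step of an at least 2.7-fold higher number from compound 1 to compound 3 (0.43 log units; beyond the scatter) is likewise bounded by that limit. Compound 4 differs from compound 3 by butyl in place of 4-chlorophenyl on a saturated chain carbon bound to an amide-type nitrogen, the same change in the same place as that from compound 1 to compound 2. Because compound 3 already sits at > 100000 nM and the earlier step of an at least 2.7-fold higher number from compound 1 to compound 2 (0.43 log units; beyond the scatter) raised the number, compound 4 is expected to stay at or beyond the limit, so the expected step that the limit leaves unreadable from compound 3 to compound 4 is modest and the estimate for compound 4 is 150000 nM.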

Compound 4, half-maximal inhibitory concentration: > 100000 nM
Compound 4 ended at the assay's limit (the forecaster's own chance of this, stated with the estimate: 85%); the middle value is on the limit's open side.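

Compound 4 also returns only a limit, so neither the step from compound 3 to compound 4 nor that from compound 2 to compound 4 can be read: the limit of > 100000 nM in this assay, at which 3 of the 4 values shown sit.

The compounds shown leave open how compound 2, compound 3 and compound 4 truly rank in this assay.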